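This account rests on a few compounds, and the source may have more. Where it says the series, first, only, none or still open, it means among the compounds named here.

Measured compounds in the series:

- compound 1 `Cn1cc(-c2cnc(N)c(Oc3ccc(C(=O)Nc4ccccc4Cl)cc3)n2)cn1`: 41400 nM
- compound 2 `Cn1cc(-c2cnc(N)c(Oc3ccc(C(=O)Nc4cccc(Cl)c4)cc3)n2)cn1`: 24500 nM

Among the measured compounds shown here, in a functional assay on LoVo cells (Homo sapiens) for inhibition, read by MTT assay, with a stated time of 72 h (on this read-out lower numbers stand for stronger inhibition and higher numbers for weaker inhibition), compound 2 gives 24500 nM, the lowest of the two numbers at hand; its only neighbour is compound 1 at 41400 nM, and the step of a 1.7-fold lower number from compound 1 to compound 2 (0.23 log units; within the scatter) is within the scatter, so the two compounds are not distinguished by this read-out.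

Compound 3 `Cn1cc(-c2cnc(N)c(Oc3ccc(C(=O)Nc4cccc(Cl)n4)cc3)n2)cn1` is not yet measured. It differs from compound 2 in one place: 6-chloropyridin-2-yl in place of 3-chlorophenyl on an amide-type nitrogen. For the measured compounds named here, the single measured step, a 1.7-fold lower number from compound 1 to compound 2 (0.23 log units; within the scatter), concerns only where the chlorine sits on the phenyl ring and says nothing about exchanging a carbon of that ring for a nitrogen; it bears on the present change only in showing that small edits at the amide-type nitrogen have so far moved the number little. Going by the values given here, no step tests the carbon-to-nitrogen exchange itself.

On that basis no step beyond the scatter is expected in this assay, in either direction, and the estimate for compound 3 is 25000 nM (range 8000 nM to 80000 nM), a step of a 1.0-fold higher number from compound 2 to compound 3 (0.01 log units; within the scatter) from compound 2 to compound 3 that is expected to stay within the scatter.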

Compound 3, half-maximal inhibitory concentration: 48600 nM
Compound 3: middle estimate off by 1.9-fold (0.29 log units), on the low side; measured number inside the range.
By their numbers in this assay, from the lowest: compounds 2, 1 and 3 (each within the scatter of the next).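

Working notes on the aryl group on the amide-type nitrogen: compound 3 gives the first reading of a ring nitrogen at this position, and in this assay the exchange of 3-chlorophenyl for 6-chloropyridin-2-yl gives a 2.0-fold higher number from compound 2 to compound 3 (0.30 log units; within the scatter) and so does not separate the two compounds. The comparison with the 2-chlorophenyl compound gives a 1.2-fold higher number from compound 1 to compound 3 (0.07 log units; within the scatter) on the same read-out, so neither the place of the chlorine on the phenyl ring nor this ring nitrogen, which brings one hydrogen-bond acceptor by the count, yields a difference that this assay can resolve among compounds 1, 2 and 3. No supporting measurement at hand bears on these numbers.

All three compounds keep a chlorine on a six-membered aromatic ring, so the compounds shown leave open whether a methoxy group, a primary amine or a carboxylic acid in place of that chlorine would give a step beyond the scatter. Also open, going by these compounds, is how the read-out responds when the aromatic ring on the amide-type nitrogen gives way to a saturated ring such as piperidine or to a longer alkyl chain.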